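Urea series: methyl to methylsulfanyl on the aryl urea

This account rests on a few compounds, and the source may have more. Where it says the series, first, only, none or still open, it means among the compounds named here.

Measured compounds, with their numbers in a functional assay on CRL2813 cells (Homo sapiens) for cytotoxicity, read by sulforhodamine B assay, with a stated time of 5 days; on this read-out lower numbers stand for stronger inhibition and higher numbers for weaker inhibition:

Compound 1, `O=C(Nc1ccccc1C(=O)O)N[C@H]1CC[C@@H](Oc2ccc(F)cc2)CC1`, gives > 20000 nM.
Compound 2, `Cc1cccc(NC(=O)N[C@H]2CC[C@H](Oc3ccc(F)cc3)CC2)c1`, gives 14400 nM.
Compound 3, `O=C(Nc1cccc(C(F)(F)F)c1)N[C@H]1CCC[C@H](Oc2ccc(C(F)(F)F)cc2)C1`, gives 3800 nM.

For compound 1 the entry is a limit of this assay, not a number (the limit of > 20000 nM in this assay, at which 1 of the 3 values shown sits). Among the two numbers that are actual values, compound 2 stands highest; compound 3 gives the lower number, and that gap lies beyond the usual scatter. For the measured compounds named here, no single-point step between measured compounds is available here, so the step to compound 4 is judged from the change alone.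

Compound 4, `CSc1cccc(NC(=O)N[C@H]2CC[C@H](Oc3ccc(F)cc3)CC2)c1`, is not yet measured. It differs from compound 2 in one place:

methylsulfanyl in place of methyl on an aromatic carbon

The change keeps the shared core of compound 2 and the urea intact and only exchanges the substituent on the aryl ring. With nothing in the measured set to calibrate such an exchange, no step beyond the scatter is expected in this assay; if anything, a small shift toward a lower number is estimated, within scatter, as a 1.4-fold lower number from compound 2 to compound 4 (0.16 log units; within the scatter). For compound 4 the expected value is 10000 nM, with a range from 4000 nM to 25000 nM.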

Compound 4, half-maximal inhibitory concentration: 11100 nM
Estimate against measurement, compound 4: 1.1-fold (0.05 log units) below; the range from low to high includes it.
By their numbers in this assay, from the lowest: compound 3; then compounds 4 and 2 (each within the scatter of the next). At a limit, above all of these: compound 1.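

In this assay, the exchange of methyl for methylsulfanyl on an aromatic carbon, meta to a large group, gives a 1.3-fold lower number from compound 2 to compound 4 (0.11 log units; within the scatter). For the compounds shown here, this is the first single-point step, and it shows that the aryl urea carries the added sulfur and the hydrogen-bond acceptor it brings without a step that can be told from repeat measurement, while the shared core and the urea stay unchanged. Compound 1 is the only entry that is a limit of this assay and not a number, so this reading of the position rests on two actual values and not on that entry: the limit of > 20000 nM in this assay, at which 1 of the 4 values shown sits.

On these data alone, it remains open whether the flat result holds for other groups at this place on the aromatic ring, such as an amine, a methylsulfonyl group or a longer chain like ethylsulfanyl, any of which would test how much change the position accepts. Compound 3 differs from compound 2 in more than one place, so its lower number cannot be credited to the aryl substituent, and what sets that gap remains unresolved in the compounds shown.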